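The compounds below may be only part of what the source reports. "The series", "measured", "known", "first", "only" and "open" are said of these compounds alone.

Compound 1 `Nc1nc(N)c2cc(CSC(=S)N3CCN(C4CCCCC4)CC3)ccc2n1` and compound 2 `Nc1nc(N)c2cc(CSC(=S)N3CCN(c4ccccc4F)CC3)ccc2n1` share one core and differ only in the group on an amine nitrogen in a ring. In a functional assay on MCF7 cells (Homo sapiens) for antiproliferative activity, read by MTT assay, with a stated time of 72 h (a lower number here means a stronger inhibitor, a higher number a weaker inhibitor), compound 1 gives 6800 nM, while compound 2 gives 4840 nM; the change a 1.4-fold lower number from compound 1 to compound 2 (0.15 log units; within the scatter) leaves compound 2 with the lower of the two numbers, yet that difference lies within the scatter. Compound 3 `Nc1nc(N)c2cc(CSC(=S)N3CCN(c4ccc(C(F)(F)F)cc4)CC3)ccc2n1` carries 4-(trifluoromethyl)phenyl in place of 2-fluorophenyl on an amine nitrogen in a ring. For the measured compounds named here, the only measured step that bears on this change is a 1.4-fold lower number from compound 1 to compound 2 (0.15 log units; within the scatter), which was small, so for compound 3 no movement beyond the scatter is expected, an estimated step of a 1.1-fold lower number from compound 2 to compound 3 (0.03 log units; within the scatter). Compound 3 is therefore estimated at 4500 nM, ranging from 1500 nM to 13000 nM.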

Compound 3, half-maximal inhibitory concentration: 7400 nM
The estimate for compound 3 lay 1.6-fold (0.22 log units) below the measured number; low and high end bracket the measured number.
By their numbers in this assay, from the lowest: compounds 2, 1 and 3 (each within the scatter of the next).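

The step to 4-(trifluoromethyl)phenyl on this amine nitrogen is a 1.5-fold higher number from compound 2 to compound 3 (0.18 log units; within the scatter) in this assay, and measured against the cyclohexyl group it is a 1.1-fold higher number from compound 1 to compound 3 (0.04 log units; within the scatter) as well. Cyclohexyl, 2-fluorophenyl and 4-(trifluoromethyl)phenyl therefore cannot be told apart at this position in this assay, although one is a non-aromatic ring and two are fluorinated aromatic rings. No supporting measurement is available to explain these numbers. From the compounds shown here alone, whether a carboxylic acid, an amine or a longer chain on this nitrogen would move the number beyond the scatter stays open.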